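Dropping the isobutoxy group from a bis-chromone

This account rests on a few compounds, and the source may have more. Where it says the series, first, only, none or still open, it means among the compounds named here.

Measured compounds:
- Compound 1, `CC(C)COc1cccc2occ(Cc3coc4ccccc4c3=O)c(=O)c12`, > 10000 nM in a functional assay on MDA-MB-231 cells (Homo sapiens) for antiproliferative activity, read by XTT assay; a lower number here means a stronger inhibitor, a higher number a weaker inhibitor
- Compound 2, `O=c1c(Cc2coc3cccc(OCC4CCCCC4)c3c2=O)coc2cc(O)ccc12`, 3220 nM
- Compound 3, `O=c1c(CCc2coc3ccccc3c2=O)coc2ccccc12`, > 10000 nM

All three compounds were tested for how strongly they slow the growth of a breast-cancer cell line. For compound 1 the value of > 10000 nM is a limit of the assay, not a measured number. Compound 3 likewise sits at the limit of > 10000 nM. Going by the values given here, compound 2 is the only one with a measured value, 3220 nM. On the numbers shown, compound 1 therefore stands at the weak end, where (the limit of > 10000 nM in this assay, at which 2 of the 3 values shown sit).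

Compound 4, `O=c1c(Cc2coc3ccccc3c2=O)coc2ccccc12`, differs from compound 1 by hydrogen in place of isobutoxy on an aromatic carbon. Among the compounds with values here, no step between measured compounds covers this change, so its direction cannot be read from the data. Compound 3, also lacking substituents on both ring systems, gives only a limit, which suggests the unsubstituted core is weak in this assay. Compound 4 is therefore expected to remain near the limit; the estimated step that the limit leaves unreadable from compound 1 to compound 4 is expected to be small. The estimate for compound 4 is 15000 nM, with a range from 5000 nM to 50000 nM.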

Compound 4, half-maximal inhibitory concentration: > 10000 nM
Compound 4 was reported as a limit (the forecaster's own chance of this, stated with the estimate: 70%); the middle value lies beyond the limit too.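

Compound 1 and compound 4 both sit at a limit of the assay rather than at a measured number, so no step can be read from losing the isobutoxy group: the limit of > 10000 nM in this assay, at which 3 of the 4 values shown sit.

The compounds shown leave open whether the isobutoxy group makes any difference at all in this assay.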